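Replacing the Nitrophenyl Cap: A Step Between Two Limits

The source may hold more compounds than are shown below. What is called first, only, known or untested is meant among the compounds shown, and "the series" means these compounds.

Measured so far in a functional assay on MGC-803 cells (Homo sapiens) for inhibition, read by MTT assay, with a stated time of 72 h; on this read-out lower numbers stand for stronger inhibition and higher numbers for weaker inhibition:
compound 1, `CC(C)n1ncc2c(C(=O)NCc3cn(-c4ccccc4)nn3)cccc21`: > 40000 nM
compound 2, `CC(C)n1ncc2c(C(=O)NCc3cn(-c4ccc([N+](=O)[O-])cc4)nn3)cccc21`: > 40000 nM

Both of these numbers are limits of this assay, not measured values. Compound 2 thus stands only at a limit. Among the measured compounds shown here, the one other value shown is a limit as well, so the step that the two limits leave unreadable from compound 1 to compound 2 cannot be read in either direction or size. What the record holds is summed up by the limit of > 40000 nM in this assay, at which 2 of the 2 values shown sit.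

Compound 3, `CC(C)n1ncc2c(C(=O)NCc3cn(-c4ccccc4F)nn3)cccc21`, differs from compound 2 by 2-fluorophenyl in place of 4-nitrophenyl on an aromatic nitrogen. For the measured compounds named here, no measured step bears on this change; the only recorded step is itself unreadable, so there is nothing from which a size or direction in this assay can be taken.

Because of the limit of > 40000 nM in this assay, at which 2 of the 2 values shown sit, compound 3 is expected to reach only the limit again. Compound 3 is estimated at 40000 nM, with a range from 15000 nM to 100000 nM, and the expected step of a number no higher from compound 2 to compound 3 (the limit leaves the size open) is therefore none beyond the scatter.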

Compound 3, half-maximal inhibitory concentration: > 40000 nM
Compound 3: a limit, no number; the forecaster's own chance of this, stated with the estimate: 80%; the middle value sits exactly at the limit.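

Among the compounds shown here, compound 3 sits in this assay at > 40000 nM and this is a limit, not a number, so no step among compound 1, compound 2 and compound 3 can be read. The compounds shown leave open whether 2-fluorophenyl or 4-nitrophenyl changes inhibition at all, since all that stands is: the limit of > 40000 nM in this assay, at which 3 of the 3 values shown sit.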